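The source may report more compounds than this note shows. Statements on the series, on what has been measured and on what is new or still open speak of the compounds shown alone.

In a physicochemical assay for solubility, read by LC-MS, in phosphate buffer, with a stated time of 24 h, at pH 7.4 (on this read-out lower numbers stand for lower solubility and higher numbers for higher solubility), compound 1 `O=C(Nc1cnc(NCc2c(F)ccc3c2CCO3)n2cnnc12)c1cccnc1` gives 12000 nM and compound 2 `O=C1CC2(CC2)CN1c1cnc(NCc2c(F)ccc3c2CCO3)n2cnnc12` gives 130000 nM, the higher of the two numbers. Compound 3 `O=C1CCCN1c1cnc(NCc2c(F)ccc3c2CCO3)n2cnnc12` has not been measured yet. It differs from compound 2 in one place, on an aromatic carbon: a group of 6 heavy atoms (4 carbon, 1 nitrogen, 1 oxygen; one five-membered non-aromatic ring with 1 hetero atom) in place of a group of 8 heavy atoms (6 carbon, 1 nitrogen, 1 oxygen; one three-membered non-aromatic ring of carbon only, one five-membered non-aromatic ring with 1 hetero atom), on an aromatic carbon. The entering 2-oxopyrrolidin-1-yl group has the five-membered ring but not the three-membered ring of carbon. Going by the values given here, the only measured step is an 11-fold higher number from compound 1 to compound 2 (1.03 log units; beyond the scatter), which is large and beyond the scatter. That step exchanged a group with a six-membered aromatic ring for the group on compound 2, so it does not test the loss of the three-membered ring. With no direct comparison available, only a small upward change is expected in this assay. The estimated change is a 1.2-fold higher number from compound 2 to compound 3 (0.09 log units; within the scatter), which may not stand clear of the scatter. The expected value for compound 3 is 160000 nM, with an estimated range of 70000 nM to 360000 nM.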

Compound 3, solubility: 640000 nM
Beside the measured number, compound 3's estimate is 4.0-fold (0.60 log units) below it; the whole stated range lies below it.
By their numbers in this assay, from the lowest: compound 1; then compound 2; then compound 3.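

In this assay, a change confined to the group on the aromatic carbon gives a 4.9-fold higher number from compound 2 to compound 3 (0.69 log units; beyond the scatter): the five-membered ring stays and only the three-membered ring of carbon goes, so this position responds even to that small edit. Against the ((pyridin-3-yl)carbonyl)amino group, the plain 2-oxopyrrolidin-1-yl group gives a 53-fold higher number from compound 1 to compound 3 (1.73 log units; beyond the scatter) and leaves compound 3 with the highest number of the three compounds. Nothing measured here explains why the number rises.

One pair cannot tell whether the rise follows the loss of that particular ring or simply a smaller group at this place. On these data alone, how an open chain such as acetylamino or a six-membered 2-oxopiperidin-1-yl group would compare on the same carbon also remains open.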